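The compounds below may be only part of what the source reports. "The series", "measured", "known", "first", "only" and "open" are said of these compounds alone.

Measured compounds in an ADME assay on J774.A1 cells (Mus musculus) for cytotoxicity, read by MTT assay, with a stated time of 48 h; on this read-out lower numbers stand for higher toxicity in this test and higher numbers for lower toxicity in this test:
compound 1 `COc1ccc(CNC(=O)c2c([N+](=O)[O-])noc2-c2ccc(Cl)cc2)cc1OC` gives 106000 nM
compound 2 `COc1ccc(CNC(=O)c2c([N+](=O)[O-])noc2-c2ccc(Cl)cc2Cl)cc1OC` gives 81800 nM
compound 3 `COC(=O)c1c(NCc2ccccc2)noc1-c1ccc(Cl)cc1Cl` gives 54200 nM

Compound 1 and compound 2 share one core; compound 3 has another, and the difference between the two cores is not broken down here. From compound 1 to compound 2 the change is chloro in place of hydrogen on an aromatic carbon; it made a 1.3-fold lower number from compound 1 to compound 2 (0.11 log units; within the scatter). Compound 3 stands close to both, within the scatter of each.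

Compound 4 `COC(=O)c1c(NCc2ccc(Cl)cc2)noc1-c1ccc(Cl)cc1Cl` is not yet measured. It differs from compound 3 by chloro in place of hydrogen on an aromatic carbon. This is the same kind of change as from compound 1 to compound 2, but not the same: there the entering chloro sits ortho to a large group and meta to a chloro group, here para to a large group. Since that earlier step stayed within the scatter, the step from compound 3 to compound 4 is expected to be small as well, about a 1.2-fold lower number from compound 3 to compound 4 (0.08 log units; within the scatter). Compound 4 is estimated at 45000 nM, between 20000 nM and 100000 nM.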

Compound 4, half-maximal cytotoxic concentration: 176000 nM
The estimate for compound 4 lay 3.9-fold (0.59 log units) below the measured number; the whole stated range lies below it.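

In this assay chloro in place of hydrogen on an aromatic carbon gave a 3.2-fold higher number from compound 3 to compound 4 (0.51 log units; beyond the scatter) and did not carry over unchanged between the two cores: the same change on two cores in this assay, a 1.3-fold lower number (0.11 log units; within the scatter) from compound 1 to compound 2 and a 3.2-fold higher number (0.51 log units; beyond the scatter) from compound 3 to compound 4, 4.2-fold (0.62 log units) apart, beyond the scatter of two such steps

The entering chloro also sits in a different place in the two steps, so these compounds do not separate the effect of the core from that of the place. With one pair on each core, the size and direction of this step cannot be assumed from one core to the other, and no rule for either core follows.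

Open, as far as these compounds go, is whether fluoro or a methyl group, para to a large group, would move the number as chloro does. Also open, from the compounds shown here alone, is whether the step holds with a carboxylic acid in place of the methyl ester of compound 3.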